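Two limits and a hydroxy-bearing ring

The source may report more compounds than this note shows. Statements on the series, on what has been measured and on what is new or still open speak of the compounds shown alone.

Measured in an ADME assay on DU-145 cells (Homo sapiens) for cytotoxicity, read by MTT assay, with a stated time of 72 h; on this read-out lower numbers stand for stronger inhibition and higher numbers for weaker inhibition:
- Compound 1 `COC(=O)c1cc(C2=C(c3cc(OC)c(OC)c(OC)c3)C(=O)CC2O[SiH2]C(C)(C)C)ccc1OC`: > 100 ug/mL, a limit
- Compound 2 `COc1cc(C2=C(c3ccccc3)C(O[SiH2]C(C)(C)C)CC2=O)cc(OC)c1OC`: > 100 ug/mL, a limit

Compound 2 stands at the limit of > 100 ug/mL in this assay, at which 2 of the 2 values shown sit, so it has a limit and no actual number. Compound 3 `COc1ccc(C2=C(c3cc(OC)c(OC)c(OC)c3)C(=O)CC2O[SiH2]C(C)(C)C)cc1O` has 3-hydroxy-4-methoxyphenyl in place of phenyl on a double-bonded ring carbon. For the measured compounds named here, only one measured step concerns this same ring carbon. It is a step that the two limits leave unreadable from compound 1 to compound 2, with phenyl in place of 4-methoxy-3-(methoxycarbonyl)phenyl. That step has no readable size, so it offers no size to carry over, and the expectation stays loose. Compound 3 may show stronger inhibition in this assay, or it may stay at the limit. The expected move is an at least 5.0-fold lower number from compound 2 to compound 3 (0.69 log units; beyond the scatter). For compound 3 the estimated value is 20 ug/mL, with an expected range from 0.5 ug/mL to 100 ug/mL.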

Compound 3, half-maximal inhibitory concentration: 75 ug/mL
Beside the measured number, compound 3's estimate is 3.8-fold (0.57 log units) below it; low and high end bracket the measured number.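

In this assay, for the compounds shown here, compound 3 gives 75 ug/mL, the first actual number for a group on this double-bonded ring carbon. Replacing phenyl with 3-hydroxy-4-methoxyphenyl gives an at least 1.3-fold lower number from compound 2 to compound 3 (0.12 log units; that floor lies within the scatter), and putting hydroxy in place of methoxycarbonyl on the aromatic carbon gives an at least 1.3-fold lower number from compound 1 to compound 3 (0.12 log units; that floor lies within the scatter). Only these floors can be read, so neither change is shown to exceed the usual scatter, and neither is capped in size, as compound 1 and compound 2 both sit at a limit: the limit of > 100 ug/mL in this assay, at which 2 of the 3 values shown sit.

From the compounds shown here alone, whether an amine or a carboxylic acid in place of the hydroxy would move the number further from the limit stays open. Also open, going by these compounds, is how actual numbers for compound 1 and compound 2 would compare with compound 3.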